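Bromo Gives Way to Iodo in Compound 4

A few compounds are considered here, and "the series" means these few. Any claim that something is new, unique, unknown or untested is made for them only; others in the source may bear on it.

In a functional assay on DU-145 cells (Homo sapiens) for inhibition, read by trypan blue exclusion, with a stated time of 96 h (on this read-out lower numbers stand for stronger inhibition of growth and higher numbers for weaker inhibition of growth), three compounds sharing one core differ only in the group on a double-bonded chain carbon. Compound 1 `O=C(/C(=C\c1csc([N+](=O)[O-])c1)S(=O)(=O)c1ccc(Br)cc1)c1ccc(Br)cc1` gives 1000 nM with 5-nitrothiophen-3-yl at that place. Compound 2 `O=C(/C(=C\c1ccc(Cl)c([N+](=O)[O-])c1)S(=O)(=O)c1ccc(Br)cc1)c1ccc(Br)cc1` gives 10000 nM with 4-chloro-3-nitrophenyl there. Compound 3 `O=C(/C(=C\c1ccc(Br)cc1)S(=O)(=O)c1ccc(Br)cc1)c1ccc(Br)cc1` gives 10000 nM with 4-bromophenyl, level with compound 2 at the digits reported, and these two share the highest number of the three.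

Compound 4 `O=C(/C(=C\c1ccc(I)cc1)S(=O)(=O)c1ccc(Br)cc1)c1ccc(Br)cc1` has not yet been measured. Its change from compound 3 is iodo in place of bromo on an aromatic carbon and amounts to iodo in place of bromo on an aromatic carbon, turning 4-bromophenyl into 4-iodophenyl. Among the measured compounds shown here, no measured step makes this exact exchange, so the steps at the same place serve as the guide. The modest steps of a 10-fold higher number from compound 1 to compound 2 (1.00 log units; beyond the scatter) and a 10-fold higher number from compound 1 to compound 3 (1.00 log units; beyond the scatter) both start from the 5-nitrothiophen-3-yl group, which compound 4 does not carry. The step between the two phenyl compounds shows no change at the digits printed from compound 2 to compound 3 (within the scatter) and is the closer guide, so no step beyond the scatter is expected in this assay. The estimated step is a 1.3-fold lower number from compound 3 to compound 4 (0.10 log units; within the scatter) and is expected to be small. For compound 4 the expected value is 8000 nM, with an estimated range from 2500 nM to 25000 nM.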

Compound 4, concentration for 50% growth inhibition: 1000 nM
Compound 4: the middle estimate sits 8.0-fold (0.90 log units) above what was measured; the whole stated range lies above it.
By their numbers in this assay, from the lowest: compounds 1 and 4 (each within the scatter of the next); then compounds 2 and 3 (each within the scatter of the next).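

In this assay, among the compounds shown here, the position proves sensitive to a single halogen exchange, which the earlier compounds had not tested: iodo in place of bromo on an aromatic carbon, para to a large group, gives a 10-fold lower number from compound 3 to compound 4 (1.00 log units; beyond the scatter) and so separates two groups that differ by one heavy atom each, with no ring, donor, acceptor or charge entering or leaving. The exchange also parts compound 4 from the nitro-bearing phenyl compound, with a 10-fold lower number from compound 2 to compound 4 (1.00 log units; beyond the scatter) as the step, whereas 4-bromophenyl had shown no such separation from 4-chloro-3-nitrophenyl. Until now the lower number had appeared only with 5-nitrothiophen-3-yl, but the comparison with 4-iodophenyl reads no change at the digits printed from compound 1 to compound 4 (within the scatter) and shows that a plain halogen-bearing phenyl group can stand with it.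

On these data alone, how 4-chlorophenyl, 4-fluorophenyl or 4-aminophenyl would fall at this place remains open, as does whether iodo in place of bromo on the other bromine-bearing aromatic rings of the shared core would give a like step. No measurement at hand bears on what lies behind the step from bromo to iodo.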